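Cytotoxicity After Changing the Ring on the Core Nitrogen

A few compounds are considered here, and "the series" means these few. Any claim that something is new, unique, unknown or untested is made for them only; others in the source may bear on it.

Three compounds share one core. Compound 1 `Cc1ccccc1-c1nn(-c2ccc(N)cc2)cc1CNCCN1CCN(C)CC1` was tested in an ADME assay on Huh-7 cells (Homo sapiens) for cytotoxicity; a higher number here means that more compound is tolerated, a lower number that less compound is tolerated. In this assay compound 1 gives > 20000 nM, which is a limit of the assay and not a number. Compound 2 `CSc1ccc(-n2cc(CNCCN3CCN(C)CC3)c(-c3ccccc3C)n2)cc1` gives 17000 nM in this assay. Compound 3 `Cc1ccccc1-c1nn(-c2ccccc2Cl)cc1CNCCN1CCN(C)CC1` stands at > 20000 nM in this assay, again a limit rather than a number. The step of an at least 1.1-fold lower number from compound 1 to compound 2 (0.07 log units; that floor lies within the scatter) is small, the step of an at least 1.1-fold higher number from compound 2 to compound 3 (0.07 log units; that floor lies within the scatter) is likewise small, and a step that the two limits leave unreadable from compound 1 to compound 3. Compound 4 `Cc1ccccc1-c1nn(-c2ccc(F)c(F)c2)cc1CNCCN1CCN(C)CC1` carries 3,4-difluorophenyl in place of 2-chlorophenyl on an aromatic nitrogen. Because compound 3 sits at the limit of > 20000 nM in this assay, at which 2 of the 3 values shown sit, and the steps of an at least 1.1-fold lower number from compound 1 to compound 2 (0.07 log units; that floor lies within the scatter) and an at least 1.1-fold higher number from compound 2 to compound 3 (0.07 log units; that floor lies within the scatter) stay within the scatter, the expected step is a number no higher from compound 3 to compound 4 (the limit leaves the size open). Compound 4 is therefore estimated at 20000 nM, between 10000 nM and 40000 nM.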

Compound 4, half-maximal cytotoxic concentration: > 20000 nM
Compound 4: no number, only a limit (the forecaster's own chance of this, stated with the estimate: 70%); the middle value lies on the limit itself.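

Going by these compounds alone, compound 4 also gives a limit of the assay and not a number, so 3,4-difluorophenyl now joins 2-chlorophenyl and 4-aminophenyl on the aromatic nitrogen in giving no readable cytotoxic concentration: the limit of > 20000 nM in this assay, at which 3 of the 4 values shown sit. The only readable new step is an at least 1.1-fold higher number from compound 2 to compound 4 (0.07 log units; that floor lies within the scatter), and the other two steps to compound 4 cannot be read.

The compounds shown leave open what numbers compound 1, compound 3 and compound 4 would give. They also leave open whether a phenyl ring carrying a carboxylic acid at this position would change the tolerated concentration.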